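A few compounds are considered here, and "the series" means these few. Any claim that something is new, unique, unknown or untested is made for them only; others in the source may bear on it.

Series notes. Compound 1 `CCOc1cccc(F)c1-c1cccc2nc(Nc3cc(OC)c(OC)c(OC)c3)oc12` and compound 2 `COc1cc(Nc2nc3cccc(-c4ccccc4-c4cn[nH]c4)c3o2)cc(OC)c1OC` share one core and differ at a single aromatic carbon. Going by the values given here, in an assay on isolated protein for inhibition of ribosomal protein S6 kinase alpha-2 (Homo sapiens), with a stated time of 150 min (on this read-out lower numbers stand for stronger inhibition and higher numbers for weaker inhibition), compound 1 gives 490 nM; in this assay compound 2 gives 9300 nM, the highest number of the two measured so far. Among the compounds with values here, the only measured step is a 19-fold higher number from compound 1 to compound 2 (1.28 log units; beyond the scatter), so the position is clearly responsive in this assay. Compound 3 `COc1cc(Nc2nc3cccc(-c4cccc5cn[nH]c45)c3o2)cc(OC)c1OC` changes the same position again: a group of 9 heavy atoms (7 carbon, 2 nitrogen; one five-membered aromatic ring with 2 hetero atoms, one six-membered aromatic ring of carbon only) in place of a group of 11 heavy atoms (9 carbon, 2 nitrogen; one five-membered aromatic ring with 2 hetero atoms, one six-membered aromatic ring of carbon only), on an aromatic carbon, the entering group being 1H-indazol-7-yl, placed ortho to a fused ring and meta to a fused ring. Within the data shown here, no measured pair reports this exchange; the step of a 19-fold higher number from compound 1 to compound 2 (1.28 log units; beyond the scatter) bears on it only as a sign of how far this position can move. For compound 3 the expected step is a 2.3-fold lower number from compound 2 to compound 3 (0.37 log units; beyond the scatter), a moderate move towards lower numbers. Compound 3 is therefore estimated at 4000 nM, with a range from 1000 nM to 16000 nM.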

Compound 3, half-maximal inhibitory concentration: 50 nM
Estimate against measurement, compound 3: 80-fold (1.90 log units) above; the whole stated range lies above it.
By their numbers in this assay, from the lowest: compound 3; then compound 1; then compound 2.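

In this assay, going by these compounds alone, this position reaches much further than the earlier pair showed: the exchange of the leaving group for 1H-indazol-7-yl gives a 190-fold lower number from compound 2 to compound 3 (2.27 log units; beyond the scatter) and runs opposite to the only earlier step. Both groups hold one five-membered aromatic ring with 2 hetero atoms, one six-membered aromatic ring of carbon only, 1 hydrogen-bond donor and 1 hydrogen-bond acceptor, so these shared counts do not by themselves set the number, and 1H-indazol-7-yl in place of 2-ethoxy-6-fluorophenyl gives a 9.8-fold lower number from compound 1 to compound 3 (0.99 log units; beyond the scatter) and leaves compound 3 with the lowest number of the series. Nothing available gives a reason for either step.

Open, from the compounds shown here alone, is how the number responds to a methyl, an amine or a carboxylic acid on 1H-indazol-7-yl. Also open, going by these compounds, is whether the lower number of compound 3 carries over beyond isolated protein.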